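The source may hold more compounds than are shown below. What is called first, only, known or untested is meant among the compounds shown, and "the series" means these compounds.

Compound 1 `ClCc1ccc(Cn2cnc3c(Cl)ncnc32)cc1` gives 7940 nM in a functional assay on SK-MEL-28 cells (Homo sapiens) for cytotoxicity, read by sulforhodamine B assay, with a stated time of 48 h; on this read-out higher numbers stand for weaker inhibition of growth and lower numbers for stronger inhibition of growth. Compound 2 `ClCc1ccccc1Cn1cnc2ncnc(Cl)c21` gives 4460 nM. Compound 3 `ClCc1ccc(Cn2cnc3c(Cl)nc(Cl)nc32)cc1` gives 2690 nM.

Compound 1 and compound 2 are built from the same atoms joined differently; the difference between the two cores is not broken down here. Compound 3 differs from compound 1 by chloro in place of hydrogen on an aromatic carbon, and that change gave a 3.0-fold lower number from compound 1 to compound 3 (0.47 log units; beyond the scatter). Compound 4 `ClCc1ccccc1Cn1cnc2nc(Cl)nc(Cl)c21` is not yet measured in this assay. It differs from compound 2 by chloro in place of hydrogen on an aromatic carbon, the same change at a place described in the same words. A step of about the same size is expected, because the earlier step was a 3.0-fold lower number from compound 1 to compound 3 (0.47 log units; beyond the scatter), though a single example is thin ground. The expected step is a 3.0-fold lower number from compound 2 to compound 4 (0.47 log units; beyond the scatter). Compound 4 is therefore estimated at 1500 nM, most likely lying between 600 nM and 4500 nM.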

Compound 4, concentration for 50% growth inhibition: 350 nM
For compound 4 the middle estimate is 4.3-fold (0.63 log units) above the measured one; measured number outside the range, below it.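

On the core of compound 2 in this assay, chloro in place of hydrogen on an aromatic carbon gave a 13-fold lower number from compound 2 to compound 4 (1.11 log units; beyond the scatter). The number fell on both cores, so the direction of the change carried over, but its size did not: the same change on two cores in this assay, a 3.0-fold lower number (0.47 log units; beyond the scatter) from compound 1 to compound 3 and a 13-fold lower number (1.11 log units; beyond the scatter) from compound 2 to compound 4, 4.3-fold (0.64 log units) apart, beyond the scatter of two such steps The size of the step on one core was therefore a poor guide to its size on the other, although two pairs cannot show why the cores differ or whether the same direction would hold on a further core.

The compounds shown leave open whether an amine or a methyl group in the same place would also lower the number. They also leave open whether such a group would show the same difference between the two cores.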